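From 4-hydroxyphenyl to 3-hydroxyphenyl

This account rests on a few compounds, and the source may have more. Where it says the series, first, only, none or still open, it means among the compounds named here.

In a functional assay on MCF7 cells (Homo sapiens) for inhibition, read by MTT assay, with a stated time of 48 h (a higher number here means a weaker inhibitor, a lower number a stronger inhibitor), compound 1 `Brc1ccc2[nH]cc(C(c3ccccc3)c3c[nH]c4ccc(Br)cc34)c2c1` gives 5500 nM, and compound 2 `Oc1ccc(C(c2c[nH]c3ccc(Br)cc23)c2c[nH]c3ccc(Br)cc23)cc1` gives 3500 nM. Within the data shown here, these are the only two numbers available so far, and they lie within the scatter of each other, so compound 2 cannot be ranked ahead of compound 1.

Compound 3 `Oc1cccc(C(c2c[nH]c3ccc(Br)cc23)c2c[nH]c3ccc(Br)cc23)c1` has the same atoms as compound 2, joined differently: 3-hydroxyphenyl in place of 4-hydroxyphenyl on a saturated chain carbon bound to two aromatic carbons. This places 3-hydroxyphenyl in place of 4-hydroxyphenyl on a saturated chain carbon bound to two aromatic carbons. Among the measured compounds shown here, no measured pair shows a change of this kind, so the evidence is indirect. For the measured compounds named here, the only measured step is a 1.6-fold lower number from compound 1 to compound 2 (0.20 log units; within the scatter), which comes with hydroxy in place of hydrogen on an aromatic carbon and stays within the scatter. Going by the values given here, with so small a step as the sole guide, no change beyond the scatter is expected in this assay, and no clear direction can be assigned. The expected step is a 1.1-fold higher number from compound 2 to compound 3 (0.04 log units; within the scatter). For compound 3 the estimated value is 3800 nM, with an expected range from 1500 nM to 9000 nM.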

Compound 3, half-maximal inhibitory concentration: 2800 nM
For compound 3 the middle estimate is 1.4-fold (0.13 log units) above the measured one, and the stated range covers the measured number.
By their numbers in this assay, from the lowest: compounds 3, 2 and 1 (each within the scatter of the next).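

The exchange of 4-hydroxyphenyl for 3-hydroxyphenyl on a saturated chain carbon bound to two aromatic carbons gives, in this assay, a 1.3-fold lower number from compound 2 to compound 3 (0.10 log units; within the scatter), so this first comparison of the two hydroxyphenyl groups separates neither from the other. Set against the phenyl-bearing compound 1, the 3-hydroxyphenyl group gives a 2.0-fold lower number from compound 1 to compound 3 (0.29 log units; within the scatter), which means that the hydroxy group, in either of the two arrangements shown, has not yet produced a step that clears the scatter, even though this step is larger than a 1.6-fold lower number from compound 1 to compound 2 (0.20 log units; within the scatter). Nothing measured here offers an explanation for these small steps, and no supporting data bear on them.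

Going by these compounds, it remains open whether any group at this aromatic ring can move the number beyond the scatter, for example an amine, a carboxylic acid or a methoxy group in place of the hydroxy group. The compounds shown also share both bromo groups on the core, so they leave unanswered how a hydrogen or a chloro group in those places would read in this assay.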